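Swapping a Fluorophenyl Arm for an Ethynyl Group

The source may hold more compounds than are shown below. What is called first, only, known or untested is meant among the compounds shown, and "the series" means these compounds.

Measured compounds:
Compound 1, `O=C(Nc1ccc(F)cc1)c1cc(=O)[nH]c2cc(Br)ccc12`, gives > 20000 nM in a functional assay on KYSE-70 cells for antiproliferative activity against KYSE-70 cell line (Homo sapiens), read by MTT assay, with a stated time of 72 h; a lower number here means a stronger inhibitor, a higher number a weaker inhibitor.
Compound 2, `O=C(Nc1cccc(F)c1)c1cc(=O)[nH]c2cc(Br)ccc12`, gives 8900 nM.
Compound 3, `O=C(Nc1cccc(F)c1)c1cc(=O)[nH]c2cc(-c3ccccc3F)ccc12`, gives > 20000 nM.

Compound 3 stands at the limit of this assay; its value is not a number but a limit. Of the three values shown, two sit at that limit, as the limit of > 20000 nM in this assay, at which 2 of the 3 values shown sit, records. Going by the values given here, compound 2 is the only one with a measured number. The step of an at least 2.2-fold lower number from compound 1 to compound 2 (0.35 log units; beyond the scatter) came from 3-fluorophenyl in place of 4-fluorophenyl on an amide-type nitrogen. The step of an at least 2.2-fold higher number from compound 2 to compound 3 (0.35 log units; beyond the scatter) came from 2-fluorophenyl in place of bromo on an aromatic carbon, and this is the step that bears on what follows.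

Compound 4, `C#Cc1ccc2c(C(=O)Nc3cccc(F)c3)cc(=O)[nH]c2c1`, is not yet measured. It differs from compound 3 by ethynyl in place of 2-fluorophenyl on an aromatic carbon. The change undoes the enlargement that took compound 2 to compound 3 and puts a small group back at the same place. Since the bromo compound 2 was the one measured below the limit, the ethynyl compound 4 is expected to move back toward it, giving an at least 2.0-fold lower number from compound 3 to compound 4 (0.30 log units; that floor lies within the scatter). Compound 4 is therefore estimated at 10000 nM, within 4000 nM to 25000 nM, with a real chance that it again returns only a limit.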

Compound 4, half-maximal inhibitory concentration: 9500 nM
The estimate for compound 4 lay 1.1-fold (0.02 log units) above the measured number, within the range that was stated.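

In this assay, ethynyl in place of 2-fluorophenyl on this aromatic carbon gives an at least 2.1-fold lower number from compound 3 to compound 4 (0.32 log units; beyond the scatter), so the loss seen with the 2-fluorophenyl group is not a lasting feature of the position: it goes away when a group with no ring stands there. The comparison with the bromo compound gives a 1.1-fold higher number from compound 2 to compound 4 (0.03 log units; within the scatter), so in this assay ethynyl and bromo cannot be told apart on this carbon, and the position does not depend on a halogen to keep a measurable value. Compound 3 gives > 20000 nM, which is a limit and not a number, so the step from it is only a floor: the limit of > 20000 nM in this assay, at which 2 of the 4 values shown sit.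

The compounds shown leave open whether anything on this carbon goes beyond the level shared by compound 2 and compound 4, for instance a nitrile, a carboxylic acid, an amine or a longer alkyne chain, and whether the loss in compound 3 belongs to the phenyl ring or to its fluorine. They also leave open whether the step from 4-fluorophenyl to 3-fluorophenyl on the amide nitrogen holds with ethynyl in place of bromo.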